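Difluorophenyl for methoxyphenyl on the chain carbon

The source may hold more compounds than are shown below. What is called first, only, known or untested is meant among the compounds shown, and "the series" means these compounds.

Of the compounds shown here, three have been measured in an in vitro functional assay on cells for agonist activity at Bombesin receptor subtype-3 (Homo sapiens), read by luminescence and calcium flux; a higher number here means that more compound is needed for the effect, a lower number that less compound is needed. Compound 1 `CCCCc1cnc(CCCc2ccc(-c3ccccc3C(=O)O)cc2)[nH]1` gives 5600 nM, compound 3 `CCCCc1cnc(C(Cc2ccc(-c3ccccc3C(=O)O)cc2)C(C)C)[nH]1` gives 4620 nM, and compound 2 `COc1ccc(Cc2cnc(CCc3ccc(-c4ccccc4C(=O)O)cc3)[nH]2)cc1` gives 5360 nM. Compound 2 sits between the other two on the numbers shown, but all three lie within the usual scatter of one another, so no order among them can be read. Compound 4 `O=C(O)c1ccccc1-c1ccc(CCc2ncc(Cc3cccc(F)c3F)[nH]2)cc1` is not yet measured in this assay. Its structure differs from compound 2 by 2,3-difluorophenyl in place of 4-methoxyphenyl on a saturated chain carbon bound to an aromatic carbon. Among the compounds with values here, no step between measured compounds bears on this change, so no direction is indicated, and a step from compound 2 to compound 4 beyond the scatter is not expected. The value of compound 4 is estimated at 5000 nM, within 1500 nM to 16000 nM, which means an expected step of a 1.1-fold lower number from compound 2 to compound 4 (0.03 log units; within the scatter).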

Compound 4, half-maximal effective concentration: 87 nM
Compound 4: middle estimate off by 57-fold (1.76 log units), on the high side; measured number below the stated range.
By their numbers in this assay, from the lowest: compound 4; then compounds 3, 2 and 1 (each within the scatter of the next).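

In this assay, this saturated chain carbon proves highly sensitive to its aryl group: 2,3-difluorophenyl in place of 4-methoxyphenyl gives a 62-fold lower number from compound 2 to compound 4 (1.79 log units; beyond the scatter), although both groups have 8 heavy atoms. The earlier compounds shown here, all within the scatter of one another, gave no sign of such a step. No measurement shown accounts for it.

From the compounds shown here alone, whether the step tracks loss of the methoxy group or arrival of the two fluorines remains open. Unsubstituted phenyl or a monofluorophenyl group at this carbon would separate the two.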